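Substance-P receptor binding: removing the methylpiperazine from two cores

The source may report more compounds than this note shows. Statements on the series, on what has been measured and on what is new or still open speak of the compounds shown alone.

Measured compounds in an assay on CHO cells for displacement of a labelled ligand from Substance-P receptor (Homo sapiens); a higher number here means a weaker inhibitor, a lower number a stronger inhibitor:
- compound 1 `Cc1ccccc1-c1cnccc1N(C)C(=O)C(C)(C)c1cc(C(F)(F)F)cc(C(F)(F)F)c1`: 3.3 nM
- compound 2 `Cc1ccccc1-c1ccc(N2CCN(C)CC2)nc1C(=O)N(C)Cc1cc(C(F)(F)F)cc(C(F)(F)F)c1`: 6.2 nM
- compound 3 `Cc1ccccc1-c1cnc(N2CCN(C)CC2)cc1N(C)C(=O)C(C)(C)c1cc(C(F)(F)F)cc(C(F)(F)F)c1`: 1.7 nM

Compound 4 `Cc1ccccc1-c1cccnc1C(=O)N(C)Cc1cc(C(F)(F)F)cc(C(F)(F)F)c1` is not yet measured in this assay.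

Compound 1 differs from compound 3 by hydrogen in place of 4-methylpiperazin-1-yl on an aromatic carbon, and this gave a 1.9-fold higher number from compound 3 to compound 1 (0.29 log units; within the scatter). Compound 4 differs from compound 2 by hydrogen in place of 4-methylpiperazin-1-yl on an aromatic carbon; the change is the same, made on a different core. The difference between the core of compound 2 and the core of compound 3 is not broken down here.

Among the measured compounds shown here, the expectation for compound 4 rests on the one measured step of this change. For the measured compounds named here, from compound 2 the step is estimated at a 1.9-fold higher number from compound 2 to compound 4 (0.29 log units; within the scatter), modelled on the step from compound 3 to compound 1 , with wider bounds because only one example exists. Compound 4 is expected to give about 12 nM in this assay, with a range from 5 nM to 30 nM.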

Compound 4, inhibition constant: 3.8 nM
For compound 4 the middle estimate is 3.2-fold (0.50 log units) above the measured one; measured number outside the range, below it.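

In this assay, hydrogen in place of 4-methylpiperazin-1-yl on the core of compound 2 gives a 1.6-fold lower number from compound 2 to compound 4 (0.21 log units; within the scatter). Set beside the earlier example, this change does not carry over as a fixed step between the two cores: the same change on two cores in this assay, a 1.9-fold higher number (0.29 log units; within the scatter) from compound 3 to compound 1 and a 1.6-fold lower number (0.21 log units; within the scatter) from compound 2 to compound 4, 3.2-fold (0.50 log units) apart, beyond the scatter of two such steps

Each step on its own stays within the scatter, so neither core alone shows that the 4-methylpiperazin-1-yl group matters, and two examples do not tell what separates the steps. The compounds shown leave open whether a morpholine or a simple dimethylamino group at this place would give matching steps on both cores. As far as these compounds go, whether the gap between the steps recurs on a third core also remains open.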